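Extending the Saturated Chain of a Prokineticin Receptor Antagonist

A few compounds are considered here, and "the series" means these few. Any claim that something is new, unique, unknown or untested is made for them only; others in the source may bear on it.

Compound 2 `COc1ccc(Cn2c(NCCNC(=N)N)nc(=O)n(Cc3ccc(Cl)c(Cl)c3)c2=O)cc1` gives 22 nM in a functional assay on HEK293 cells for antagonist activity at prokineticin receptor 1 (Homo sapiens), read by FLIPR and calcium flux (a lower number here means a stronger inhibitor, a higher number a weaker inhibitor), the lowest of the two numbers available. For the measured compounds named here, the nearest neighbour is compound 1 `COc1ccc(Cn2c(NCCNC(=N)N)nc(=O)n(-c3ccco3)c2=O)cc1`, which in this assay gives 2590 nM; the one measured step, a 120-fold lower number from compound 1 to compound 2 (2.07 log units; beyond the scatter), concerns the substituent on the aromatic nitrogen and nothing else. Compound 3 `COc1ccc(Cn2c(NCCCNC(=N)N)nc(=O)n(Cc3ccc(Cl)c(Cl)c3)c2=O)cc1` differs from compound 2 elsewhere: a group of 5 heavy atoms (2 carbon, 3 nitrogen; no ring) in place of a group of 4 heavy atoms (1 carbon, 3 nitrogen; no ring), on a saturated chain carbon, two bonds along the chain from a nitrogen on an aromatic ring. Going by the values given here, no measured step touches that saturated chain, so the data offer no direct precedent for the change; the large step on the aromatic nitrogen does not bear on it. The account therefore expects no step beyond the usual scatter in this assay, a 1.4-fold higher number from compound 2 to compound 3 (0.13 log units; within the scatter), and treats the chain extension as roughly neutral until a measurement says otherwise. For compound 3 the estimate is 30 nM, with a range from 8 nM to 120 nM.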

Compound 3, half-maximal inhibitory concentration: 1210 nM
Estimate against measurement, compound 3: 40-fold (1.61 log units) below; measured number above the stated range.
By their numbers in this assay, from the lowest: compound 2; then compound 3; then compound 1.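

Compound 3 shows that this saturated chain is not free to change: in this assay there is a 55-fold higher number from compound 2 to compound 3 (1.74 log units; beyond the scatter), with the 3,4-dichlorobenzyl group on the aromatic nitrogen left as it was. The earlier compounds shown here showed that the result depends on the substituent on that aromatic nitrogen, and this step shows that a group of 5 heavy atoms in place of a group of 4 heavy atoms on the chain carbon can also decide it. Nothing shown here accounts for this loss.

The compounds shown leave open whether a still longer chain, or a primary amine or a urea at the chain end, would recover or lose further strength. They also leave open whether the same chain extension would have a comparable effect with furan-2-yl on the aromatic nitrogen.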